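The source may hold more compounds than are shown below. What is called first, only, known or untested is meant among the compounds shown, and "the series" means these compounds.

In a functional assay on the whole organism with Rattus norvegicus as the target (on this read-out higher numbers stand for an effect only at larger amounts of compound and lower numbers for an effect already at smaller amounts), compound 2 (`CCN(CCNC(=O)c1cc(Cl)c(N)cc1OC)Cc1ccccn1`) stands at the weak end of what has been measured so far: compound 2 needs 30 mg/kg for a half-maximal effect, the highest number of the three. Its nearest neighbour is compound 3 (`COc1cc(N)c(Cl)cc1C(=O)NCCN(C)C(C)c1ccccc1`) with 1 mg/kg as its dose, and furthest off lies compound 1 (`CCN(CCNC(=O)c1cc(Cl)c(N)cc1OC)Cc1ccccc1`) with 0.31 mg/kg as its dose.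

The next compound, compound 4 (`CCN(CCNC(=O)c1cc(Cl)c(N)cc1OC)Cc1ccc(OC)cc1`), changes one group of compound 2 (4-methoxyphenyl in place of pyridin-2-yl on a saturated chain carbon bound to an amine nitrogen): 4-methoxyphenyl in place of pyridin-2-yl on a saturated chain carbon bound to an amine nitrogen. Among the measured compounds shown here, only one measured step touches this place. There, pyridin-2-yl in place of phenyl raised the number sharply (a 97-fold higher number from compound 1 to compound 2 (1.99 log units; beyond the scatter)), a large change well beyond the scatter. Compound 4 again carries a ring of carbon only, as compound 1 does, so much of that rise is expected to be undone. For the measured compounds named here, no measured compound carries 4-methoxyphenyl at this place, however, so the expectation remains uncertain. The expected step is therefore large and points to a lower number (a 30-fold lower number from compound 2 to compound 4 (1.48 log units; beyond the scatter)). For compound 4 the estimated dose is 1 mg/kg (expected range 0.15 mg/kg to 6 mg/kg).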

Compound 4, dose for half-maximal effect: 0.2 mg/kg
Compound 4: middle estimate off by 5.0-fold (0.70 log units), on the high side; low and high end bracket the measured number.
By their numbers in this assay, from the lowest: compounds 4 and 1 (each within the scatter of the next); then compound 3; then compound 2.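

In this assay, 4-methoxyphenyl in place of the pyridin-2-yl of compound 2 gives a 150-fold lower number from compound 2 to compound 4 (2.18 log units; beyond the scatter) and so removes the whole of the large rise seen earlier at this place, not just part of it. Adding methoxy to the carbon ring of compound 1 gives a 1.6-fold lower number from compound 1 to compound 4 (0.19 log units; within the scatter) and so makes no difference that can be told from the scatter, which shows that this place accepts a larger group on a ring of carbon only, with compound 2 alone standing apart among the benzyl-type compounds compared here. Nothing measured on these groups explains why the pyridin-2-yl ring behaves so differently.

As far as these compounds go, it remains open whether any ring nitrogen gives the same weak result or only one placed as in pyridin-2-yl, which pyridin-3-yl or pyridin-4-yl at this place would show. From the compounds shown here alone, it is equally open whether the tolerance seen for methoxy extends to other groups on the carbon ring, such as those in 4-chlorophenyl or 4-hydroxyphenyl.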